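Swapping the Sulfonamide Cap on a Shared Core

The source may report more compounds than this note shows. Statements on the series, on what has been measured and on what is new or still open speak of the compounds shown alone.

Among the compounds with values here, compound 1 `CCS(=O)(=O)Nc1ccc(-c2cc(=O)c3c(O)cc(OC)c(OC(C)C)c3o2)cc1` gives the higher of the two numbers measured so far: in a functional assay on LNCaP cells (Homo sapiens) for antiproliferative activity, read by MTT assay, with a stated time of 3 days (a higher number here means a weaker inhibitor, a lower number a stronger inhibitor), compound 1 gives 113000 nM. Compound 2 `C=CC(=O)Nc1ccc(-c2cc(=O)c3c(O)cc(OC)c(OC(C)C)c3o2)cc1` gives 15100 nM. Within the data shown here, the one step measured, a 7.5-fold lower number from compound 1 to compound 2 (0.87 log units; beyond the scatter), changed the same group as the step followed here. Compound 3 `COc1cc(O)c2c(=O)cc(-c3ccc(NC(=O)N4CC(C)NC(C)C4)cc3)oc2c1OC(C)C` differs from compound 1 in one place: (3,5-dimethylpiperazin-1-yl)carbonyl in place of ethylsulfonyl on a nitrogen on an aromatic ring. Since a carbonyl-bearing group replacing the ethylsulfonyl gave that earlier drop, a smaller lowering is expected here, a 3.2-fold lower number from compound 1 to compound 3 (0.51 log units; beyond the scatter), the new group being larger and ring-bearing. Compound 3 is therefore estimated at 35000 nM, within 10000 nM to 110000 nM.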

Compound 3, half-maximal inhibitory concentration: 2800 nM
Estimate against measurement, compound 3: 13-fold (1.10 log units) above; the whole stated range lies above it.
By their numbers in this assay, from the lowest: compound 3; then compound 2; then compound 1.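

In this assay the group on this nitrogen matters more than the first swap showed: the change to the (3,5-dimethylpiperazin-1-yl)carbonyl group gives a 40-fold lower number from compound 1 to compound 3 (1.61 log units; beyond the scatter) and, measured against the vinylcarbonyl group, a 5.4-fold lower number from compound 2 to compound 3 (0.73 log units; beyond the scatter). Compound 2 and compound 3 both place a carbonyl on this nitrogen, so a carbonyl there does not alone set the number. Nothing available explains why this group gives the lowest number of the three.

From the compounds shown here alone, it remains open whether the two methyl groups count, or whether a plain piperazin-1-yl or a morpholin-4-yl on the same carbonyl would give a similar number.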